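The source may report more compounds than this note shows. Statements on the series, on what has been measured and on what is new or still open speak of the compounds shown alone.

Compounds measured in a functional assay (Mus musculus, strain Balb/c) for inhibition, read by ELISA, with a stated time of 72 h; a higher number here means a weaker inhibitor, a lower number a stronger inhibitor:
compound 1, `COc1ccc(C(/C=C/c2ccc(Cl)cc2)=N/O)cc1`, 11500 nM
compound 2, `COc1ccc(C(/C=C/c2ccc(Cl)cc2Cl)=N/O)cc1`, 11200 nM

Compound 1 stands at the highest of the two numbers. Its nearest neighbour is compound 2, and the step of a 1.0-fold lower number from compound 1 to compound 2 (0.01 log units; within the scatter) lies within the scatter, so the two values cannot be told apart.

Compound 3, `O/N=C(\C=C\c1ccc(Cl)cc1)c1ccc(F)cc1`, has not yet been measured. Against compound 1 the change is fluoro in place of methoxy on an aromatic carbon. The exchanged group sits on an aromatic carbon of a six-membered aromatic ring of carbon only, para to a large group.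

Among the compounds with values here, only one measured step exists, chloro in place of hydrogen on an aromatic carbon, and it concerns a different ring and a different pair of groups; it does not bear on the exchange of methoxy for fluoro. That step was within the scatter, and nothing measured here speaks for a shift in either direction. No step beyond the scatter is therefore expected in this assay.

Compound 3 is estimated at 11500 nM, with a range from 4000 nM to 35000 nM. The expected step is no change at the digits printed from compound 1 to compound 3 (within the scatter), within the scatter.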

Compound 3, half-maximal inhibitory concentration: 10900 nM
The estimate for compound 3 lay 1.1-fold (0.02 log units) above the measured number; the range from low to high includes it.
By their numbers in this assay, from the lowest: compounds 3, 2 and 1 (each within the scatter of the next).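

In this assay the exchange of methoxy for fluoro, on an aromatic carbon of a six-membered aromatic ring of carbon only and para to a large group, gives a 1.1-fold lower number from compound 1 to compound 3 (0.02 log units; within the scatter). Within the data shown here, this is the first step at this position, since the earlier step concerned a different ring, and it shows that the methoxy group, with its oxygen and its hydrogen-bond acceptor, can be replaced by fluoro with no change that can be read in this measurement. No measured evidence is available to explain why the number holds across this exchange.

On these data alone, whether an amine, a carboxylic acid or a longer alkoxy chain at this same position would shift the number beyond the scatter remains open, as fluoro and methoxy alone do not show how far this position tolerates change. With every step so far within the scatter, the compounds shown also leave open which change to the shared core, if any, would move the number at all.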